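A Urea in Place of an Amide on a Shared Core

The source may report more compounds than this note shows. Statements on the series, on what has been measured and on what is new or still open speak of the compounds shown alone.

Compound 2 `COc1cc(-c2nn(-c3cccc(NC(=O)c4cccc(C(F)(F)F)c4)c3)cc2-c2ccncc2)ccc1Cl` was run in a functional assay on 786-0 cells (Homo sapiens) for inhibition, read by sulforhodamine B assay, with a stated time of 48 h; on this read-out higher numbers stand for weaker inhibition of growth and lower numbers for stronger inhibition of growth. In this assay compound 2 reaches only the limit > 50000 nM, so no number is known for it. Compound 1 `O=C(Nc1cccc(-n2cc(-c3ccncc3)c(-c3ccc(Cl)c(O)c3)n2)c1)Nc1cccc(C(F)(F)F)c1`, which carries a urea and a hydroxyl on the shared core, likewise stops at a limit: in this assay compound 1 gives > 32500 nM. For the measured compounds named here, both values shown are therefore limits rather than numbers (the limit of > 32500 nM in this assay, at which 1 of the 2 values shown sits, (the limit of > 50000 nM in this assay, at which 1 of the 2 values shown sits)), and no measured step between two numbers exists to set a scale. Compound 3 `COc1cc(-c2nn(-c3cccc(NC(=O)Nc4ccc(Cl)c(Cl)c4)c3)cc2-c2ccncc2)ccc1Cl` differs from compound 2 by (3,4-dichlorophenyl)amino in place of 3-(trifluoromethyl)phenyl on a carbonyl carbon. With both neighbours at a limit, the step from compound 2 to compound 3 is expected to be an at least 1.2-fold lower number from compound 2 to compound 3 (0.09 log units; that floor lies within the scatter), not beyond the usual scatter. Compound 3 is accordingly estimated at 40000 nM, in a range from 10000 nM to 100000 nM, and may well again be reported only as a limit.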

Compound 3, concentration for total growth inhibition: 4470 nM
For compound 3 the middle estimate is 8.9-fold (0.95 log units) above the measured one; measured number outside the range, below it.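

In this assay, (3,4-dichlorophenyl)amino in place of 3-(trifluoromethyl)phenyl on a carbonyl carbon yields the only true number among the compounds shown, and the change is a large one: an at least 11-fold lower number from compound 2 to compound 3 (1.04 log units; beyond the scatter). This step is a floor and not a full size, for compound 2 stands only at a limit: the limit of > 50000 nM in this assay, at which 1 of the 3 values shown sits. It shows that growth inhibition can be reached on this core through a change at this one place, where compound 2 gave no number.

Going by these compounds, the change brings in the amino hydrogen-bond donor and the chlorines at once, so which of them carries the step stays open. Also open, on these data alone, is whether a urea bearing 3-(trifluoromethyl)phenyl on the core of compound 2, or one bearing a plain phenyl or a pyridine ring, would give a number at all.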